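A Larger Group on the Sulfonyl Sulfur

A few compounds are considered here, and "the series" means these few. Any claim that something is new, unique, unknown or untested is made for them only; others in the source may bear on it.

Within the data shown here, in a physicochemical assay for solubility, read by spectrophotometry, measured as kinetic solubility, at pH 8, tested at 500 uM (on this read-out higher numbers stand for higher solubility and lower numbers for lower solubility), compound 2 (`Cn1ccc2ccc(-c3cc(Nc4ccccc4S(=O)(=O)Nc4cncnc4)cc4nccnc34)cc21`) gives 254 ug/mL as the higher of the two numbers so far, and compound 1 (`CN(C)S(=O)(=O)c1ccccc1Nc1cc(-c2ccc3ccn(C)c3c2)c2nccnc2c1`) gives 2 ug/mL as the lower. Compound 3 (`CN(Cc1cncnc1)S(=O)(=O)c1ccccc1Nc1cc(-c2ccc3ccn(C)c3c2)c2nccnc2c1`) has methyl((pyrimidin-5-yl)methyl)amino in place of (pyrimidin-5-yl)amino on a sulfonyl sulfur. Among the measured compounds shown here, the one measured step bearing on this (a 130-fold higher number from compound 1 to compound 2 (2.10 log units; beyond the scatter)) was large and beyond the scatter, and it started from dimethylamino. Compound 3 keeps the pyrimidine ring yet, like compound 1, carries a methyl on the nitrogen attached to sulfur. In this assay a large drop is therefore expected (a 21-fold lower number from compound 2 to compound 3 (1.33 log units; beyond the scatter)). The estimated value for compound 3 is 12 ug/mL (3 ug/mL to 60 ug/mL).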

Compound 3, solubility: 3 ug/mL
Compound 3: the middle estimate sits 4.0-fold (0.60 log units) above what was measured, within the range that was stated.
By their numbers in this assay, from the lowest: compounds 1 and 3 (each within the scatter of the next); then compound 2.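

In this assay the pyrimidine ring alone does not keep the number high: an 85-fold lower number from compound 2 to compound 3 (1.93 log units; beyond the scatter) comes with the ring still present, and placing pyrimidin-5-yl on the saturated chain carbon gives a 1.5-fold higher number from compound 1 to compound 3 (0.18 log units; within the scatter) and so stays within the scatter. The change to methyl((pyrimidin-5-yl)methyl)amino removes the hydrogen-bond donor and adds heavy atoms at once. No measurement here explains the drop. Which of these two differences counts stays open: methyl(pyrimidin-5-yl)amino would remove only the donor, while (pyrimidin-5-yl)methylamino would keep it and add only a carbon between ring and nitrogen.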